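A few compounds are considered here, and "the series" means these few. Any claim that something is new, unique, unknown or untested is made for them only; others in the source may bear on it.

Among the compounds with values here, compound 1 `CCC(=O)N1CC2CC(C1)N2` gives 180 nM in an assay on CHO cells for agonist activity at Neuronal acetylcholine receptor; alpha3/alpha6/beta2/beta3 (Homo sapiens), read by FLIPR and calcium flux (on this read-out higher numbers stand for an effect only at larger amounts of compound and lower numbers for an effect already at smaller amounts), the lowest of the two numbers measured so far. Compound 2 `CCCC(=O)N1CC2CC(C1)N2` gives 300 nM; the step of a 1.7-fold higher number from compound 1 to compound 2 (0.22 log units; within the scatter) came from a methyl in place of hydrogen on a saturated chain carbon, two bonds along the chain from a carbonyl carbon. Compound 3 `CC(C)C(=O)N1CC2CC(C1)N2` differs from compound 1 by methyl in place of hydrogen on a saturated chain carbon bound to a carbonyl carbon and a saturated chain carbon. Within the data shown here, the only step that bears on this, the one from compound 1 to compound 2, also added a methyl and stayed within the scatter, so no shift beyond the scatter is expected here. Compound 3 is therefore expected to give about 250 nM, with a range from 90 nM to 700 nM. That corresponds to an expected step of a 1.4-fold higher number from compound 1 to compound 3 (0.14 log units; within the scatter).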

Compound 3, half-maximal effective concentration: 16000 nM
Compound 3: middle estimate off by 64-fold (1.81 log units), on the low side; measured number outside the range, above it.
By their numbers in this assay, from the lowest: compounds 1 and 2 (each within the scatter of the next); then compound 3.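

Adding the methyl to the saturated chain carbon bound to the carbonyl carbon produces a large change (an 89-fold higher number from compound 1 to compound 3 (1.95 log units; beyond the scatter)), so this position does not tolerate the change as the earlier step suggested. Changing propyl to isopropyl on the carbonyl carbon also produces a large change (a 53-fold higher number from compound 2 to compound 3 (1.73 log units; beyond the scatter)), which shows that the place of the methyl on the chain matters in these three compounds. Nothing available accounts for this jump. Still open, going by these compounds, is how a cyclopropyl or tert-butyl on the carbonyl carbon would compare, and whether a hydroxyl or an amine on this chain carbon would bring a similar change.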